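Ethyl Gives Way to 3-Bromophenyl on the Shared Core

The source may hold more compounds than are shown below. What is called first, only, known or untested is meant among the compounds shown, and "the series" means these compounds.

Compound 1 `CCOC(=O)c1cnc(CC)nc1NN1C(=O)C=C(C)C1=O` gives 10000 nM in a functional assay on Jurkat cells for inhibition of nuclear factor NF-kappa-B complex (Homo sapiens) (a higher number here means a weaker inhibitor, a lower number a stronger inhibitor), the highest number among the three measured compounds. Compound 2 `CCOC(=O)c1cnc(-c2cccs2)nc1NN1C(=O)C=C(C)C1=O` gives 20 nM, and compound 3 `CCOC(=O)c1cnc(-c2ccc(Cl)cc2)nc1NN1C(=O)C=C(C)C1=O` gives 300 nM. Compound 4 `CCOC(=O)c1cnc(-c2cccc(Br)c2)nc1NN1C(=O)C=C(C)C1=O` differs from compound 1 in one place: 3-bromophenyl in place of ethyl on an aromatic carbon. Going by the values given here, two measured steps bear on this change, both replacing ethyl with an aromatic ring: a 500-fold lower number from compound 1 to compound 2 (2.70 log units; beyond the scatter) and a 33-fold lower number from compound 1 to compound 3 (1.52 log units; beyond the scatter). The two aryl compounds differ among themselves, a 15-fold higher number from compound 2 to compound 3 (1.18 log units; beyond the scatter). Compound 4 carries, as compound 3 does, a six-membered aromatic ring bearing a halogen, and compound 3 gave 300 nM. Compound 4 is therefore expected to show a large step, a 50-fold lower number from compound 1 to compound 4 (1.70 log units; beyond the scatter). Compound 4 is estimated at 200 nM, within a range from 50 nM to 1500 nM.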

Compound 4, half-maximal inhibitory concentration: 700 nM
For compound 4 the middle estimate is 3.5-fold (0.54 log units) below the measured one, and the stated range covers the measured number.
By their numbers in this assay, from the lowest: compound 2; then compound 3; then compound 4; then compound 1.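

In this assay a third aromatic ring in place of ethyl again lowers the number, with a 14-fold lower number from compound 1 to compound 4 (1.15 log units; beyond the scatter) showing that the gain is not confined to compound 2 and compound 3. Among the rings, the change from 4-chlorophenyl to 3-bromophenyl is only a modest step, a 2.3-fold higher number from compound 3 to compound 4 (0.37 log units; beyond the scatter) in size, whereas a 35-fold higher number from compound 2 to compound 4 (1.54 log units; beyond the scatter) confirms that thiophen-2-yl keeps a large lead over the 3-bromophenyl group. No evidence is available that accounts for these differences. Still open, on these data alone, is how an amine or a carboxylic acid on the ring, or a longer chain in place of ethyl, would behave at this position.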